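From 3-cyanophenyl to 4-methylphenyl: a cautious cytotoxicity estimate

The source may report more compounds than this note shows. Statements on the series, on what has been measured and on what is new or still open speak of the compounds shown alone.

- Compound 1 (`COc1cc2nc([S+]([O-])CC(=O)Nc3ccccc3[N+](=O)[O-])nc(Nc3c(Cl)cc(/C=C/C#N)cc3Cl)c2cc1OC`) gives > 199000 nM as a limit
- Compound 2 (`COc1cc2nc([S+]([O-])CC(=O)Nc3cccc(Cl)c3)nc(Nc3c(Cl)cc(/C=C/C#N)cc3Cl)c2cc1OC`) gives 68900 nM as a number
- Compound 3 (`COc1cc2nc([S+]([O-])CC(=O)Nc3cccc(C#N)c3)nc(Nc3c(Cl)cc(/C=C/C#N)cc3Cl)c2cc1OC`) gives >= 70300 nM as a limit

All three results come from an ADME assay on MT4 cells (Homo sapiens) for cytotoxicity, read by MTT assay, with a stated time of 5 days (on this read-out higher numbers stand for lower toxicity in this test and lower numbers for higher toxicity in this test), and the compounds differ in the group on an amide-type nitrogen. For compound 3 the entry >= 70300 nM is a limit and not a number.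

Compound 4 (`COc1cc2nc([S+]([O-])CC(=O)Nc3ccc(C)cc3)nc(Nc3c(Cl)cc(/C=C/C#N)cc3Cl)c2cc1OC`) has yet to be measured. It carries 4-methylphenyl in place of 3-cyanophenyl on an amide-type nitrogen, a change counted as 4-methylphenyl in place of 3-cyanophenyl on an amide-type nitrogen in full.

Within the data shown here, three measured steps bear on this swap. Among the measured compounds shown here, one gave an at least 2.8-fold lower number from compound 1 to compound 2 (0.46 log units; beyond the scatter) as its result, the only step here that is readable beyond the scatter. Another gave a step that the two limits leave unreadable from compound 1 to compound 3 and so offers no size to work with. The third, closest to the new change, gave an at least 1.0-fold higher number from compound 2 to compound 3 (0.00 log units; that floor lies within the scatter) as a floor only.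

No step beyond the scatter is therefore expected in this assay for this swap, with compound 2 at 68900 nM as the one exact anchor. The estimate amounts to a step that the limit leaves unreadable from compound 3 to compound 4 as the expected step. Compound 4 is expected at about 75000 nM with an estimated range from 30000 nM to 190000 nM in this test.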

Compound 4, half-maximal cytotoxic concentration: 32200 nM
Compound 4: middle estimate off by 2.3-fold (0.37 log units), on the high side; the range from low to high includes it.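

Among these compounds, with compound 4, a change of group on the amide-type nitrogen gives, for the first time here, a step beyond the scatter between two exact numbers in this assay (a 2.1-fold lower number from compound 2 to compound 4 (0.33 log units; beyond the scatter)), and a lower number in this read-out stands for higher toxicity in this test. Among the compounds shown here, the swap from 3-cyanophenyl to 4-methylphenyl also clears the scatter (an at least 2.1-fold lower number from compound 3 to compound 4 (0.33 log units; beyond the scatter)), whereas the step from 3-chlorophenyl to 3-cyanophenyl gave only a floor within it, and the floor for the step from 2-nitrophenyl rises as well, past the one compound 2 gave (an at least 6.1-fold lower number from compound 1 to compound 4 (0.79 log units; beyond the scatter)). The steps from compound 3 and compound 1 remain floors, because each starts from a limit and not a number, as for compound 3: (the limit of >= 70300 nM in this assay, at which 1 of the 4 values shown sits).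

Going by these compounds, what stays open is whether the lower number belongs to the methyl group itself or to where it sits on the ring, a question that 3-methylphenyl and 4-chlorophenyl groups on the same nitrogen would separate. On these data alone, how this read-out would respond to a 4-aminophenyl or a 4-carboxyphenyl group at this position also remains unknown.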